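The source may report more compounds than this note shows. Statements on the series, on what has been measured and on what is new or still open speak of the compounds shown alone.

Working notes on the series. The three measured compounds share one core, a saturated chain amide carrying an acyl group on the amine nitrogen, and differ only in that acyl group. In a functional assay on A-431 cells (Homo sapiens) for cytotoxicity, read by MTT assay, with a stated time of 48 h (on this read-out lower numbers stand for stronger inhibition and higher numbers for weaker inhibition), compound 1 `CCCCCCCCCCCCNC(=O)[C@@H](NC(=O)c1ccccc1)[C@@H](C)O` gives 41200 nM. In this assay compound 2 `CCCCCCCCCCCCNC(=O)[C@@H](NC(=O)c1ccco1)[C@@H](C)O` gives 92400 nM. In this assay compound 3 `C/C=C/C=C/C(=O)N[C@H](C(=O)NCCCCCCCCCCCC)[C@@H](C)O` gives 171000 nM. Compound 3 holds the highest number of the three: the steps are a 4.2-fold higher number from compound 1 to compound 3 (0.62 log units; beyond the scatter) and a 1.9-fold higher number from compound 2 to compound 3 (0.27 log units; within the scatter), so only its gap to compound 1 lies beyond the scatter; between the other two the step is a 2.2-fold higher number from compound 1 to compound 2 (0.35 log units; beyond the scatter).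

Compound 4 `CCCCCCCCCCCCNC(=O)[C@@H](NS(=O)(=O)c1ccc(C)cc1)[C@@H](C)O` differs from compound 3 by (4-methylphenyl)sulfonyl in place of (penta-1,3-dien-1-yl)carbonyl on an amine nitrogen. Among the compounds with values here, no measured step exchanges a carbonyl for a sulfonyl on that nitrogen, so the bearing steps are indirect ones: a 4.2-fold higher number from compound 1 to compound 3 (0.62 log units; beyond the scatter) and a 1.9-fold higher number from compound 2 to compound 3 (0.27 log units; within the scatter) show that changing the group on the amine nitrogen moves the number by modest amounts only, and compound 1, the one member carrying a six-membered aromatic ring of carbon only, holds the lowest number. From the compounds shown here alone, a modest step toward lower numbers is therefore expected, a 2.1-fold lower number from compound 3 to compound 4 (0.33 log units; beyond the scatter), with a wide range because the sulfonyl itself is untested. Compound 4 is expected to give 80000 nM in this assay, estimated between 25000 nM and 250000 nM.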

Compound 4, half-maximal inhibitory concentration: 25200 nM
Estimate against measurement, compound 4: 3.2-fold (0.50 log units) above; the measured number falls inside the stated range.
By their numbers in this assay, from the lowest: compounds 4 and 1 (each within the scatter of the next); then compounds 2 and 3 (each within the scatter of the next).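

Within the data shown here, the sulfonyl is the first linkage on this amine nitrogen that is not a carbonyl, and in this assay it sits at the low end of the series: a 6.8-fold lower number from compound 3 to compound 4 (0.83 log units; beyond the scatter) and a 3.7-fold lower number from compound 2 to compound 4 (0.56 log units; beyond the scatter) are both beyond the scatter. Against benzoyl, however, a 1.6-fold lower number from compound 1 to compound 4 (0.21 log units; within the scatter) lies within the scatter, so exchanging the carbonyl for a sulfonyl gives no separable change when a six-membered aromatic ring of carbon only is present in both compounds, and among these four compounds the two carrying that ring, compound 1 and compound 4, hold lower numbers than compound 2 and compound 3. No measurement at hand bears on why these numbers differ.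

From the compounds shown here alone, what the methyl on the ring of compound 4 contributes stays open, since a plain phenylsulfonyl on the same nitrogen would be needed to separate it from the sulfonyl itself. Also open, going by these compounds, is how the number responds to an amine or a carboxylic acid on that ring, or to a shorter chain on the amide in place of the saturated chain that all four compounds share.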